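Swapping the pyridin-2-yl group of compound 2

The source may hold more compounds than are shown below. What is called first, only, known or untested is meant among the compounds shown, and "the series" means these compounds.

Measured compounds:
compound 1 `COc1ccccc1C1CCN(CC(=O)Nc2cccc(C)c2)CC1`, 43%
compound 2 `c1ccc(C2CCN(Cc3nc4ccccc4[nH]3)CC2)nc1`, 62%

In a functional assay on HEK293 cells for agonist activity at D(4) dopamine receptor (Homo sapiens), read by FLIPR (on this read-out higher numbers stand for larger maximal responses and lower numbers for smaller maximal responses), compound 1 gives 43%, and compound 2 gives 62%. Among the compounds with values here, of the two numbers compound 2 stands highest; compound 1 is its only neighbour and lies lower by a gap beyond the usual scatter. Within the data shown here, no step between measured compounds that differ in one place has been recorded, so nothing about the size of single changes in this assay is known from these two alone.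

Compound 3 `[O-][n+]1ccccc1C1CCN(Cc2nc3ccccc3[nH]2)CC1` has not yet been measured in this assay. It differs from compound 2 in one place:
a group of 7 heavy atoms (5 carbon, 1 nitrogen, 1 oxygen; one six-membered aromatic ring with 1 hetero atom) in place of a group of 6 heavy atoms (5 carbon, 1 nitrogen; one six-membered aromatic ring with 1 hetero atom), on a saturated ring carbon
The new group keeps the single six-membered aromatic ring with one hetero atom and adds one oxygen. Among the measured compounds shown here, with no recorded step of this kind, a modest change or none beyond the scatter is expected, with a downward direction somewhat more likely than an upward one. Compound 3 is therefore expected to give about 50%, within 25% to 75%. The expected step of a number 12 percentage points lower from compound 2 to compound 3 (beyond the scatter) is estimated as a small decrease.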

Compound 3, largest response reached (reported as efficacy), in percent of the reference or control that the assay uses: 54%
The estimate for compound 3 lay 4 percentage points below the measured number; the measured number falls inside the stated range.
By their numbers in this assay, from the lowest: compound 1; then compounds 3 and 2 (each within the scatter of the next).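

In this assay, within the data shown here, the first step known between compounds that differ in one place is a number 8 percentage points lower from compound 2 to compound 3 (within the scatter). At this saturated ring carbon, three ring bonds from the ring nitrogen, the pyridin-2-yl group can thus take on one oxygen without a maximal response that can be told apart from that of compound 2. The group that enters keeps the six-membered aromatic ring with 1 hetero atom, the same count of hydrogen-bond donors and acceptors, and no net charge, but no measurement is available that would explain the result.

From the compounds shown here alone, whether a different group on the same ring carbon, such as pyridin-4-yl, cyclohexyl or a simple amine, would shift the response beyond the scatter remains open, and a single step cannot show how far this position accepts change. The compounds shown also leave open how a change elsewhere in compound 2 would act on the response, and compound 1 differs from it in more than one place, so it offers no step to compare.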